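The source may hold more compounds than are shown below. What is called first, only, known or untested is meant among the compounds shown, and "the series" means these compounds.

Measured compounds in the series:

- compound 1, `N#C[C@@H]1CCCN1C(=O)[C@@H]1C[C@H](C(=O)N2CCCCCCC2)CN1`: "not determined" (no result reported)
- compound 2, `N#C[C@@H]1CCCN1C(=O)[C@@H]1C[C@H](C(=O)N2CCCCCC2)CN1`: "not determined" (no result reported)
- compound 3, `CCN(C)C(=O)[C@@H]1CN[C@H](C(=O)N2CCC[C@H]2C#N)C1`: 34%

Three compounds share the core of compound 3, and each has been submitted to an assay on the whole organism (plasma, strain Sprague-Dawley) for inhibition of Dipeptidyl peptidase 4 (Rattus norvegicus), with a stated time of 10 h, at a dose of 1 mg/kg by the oral route; a lower number here means less inhibition, a higher number more inhibition at the dose given (going by the name of the read-out). For compound 1 and compound 2 no number is available, so the series rests on a single measured value. In this assay, within the data shown here, compound 3 gives 34%, which therefore is the only reference point; no comparison between measured compounds can be drawn, and no step between measured compounds is known.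

The next compound, compound 4, `CNC(=O)[C@@H]1CN[C@H](C(=O)N2CCC[C@H]2C#N)C1`, differs from compound 3 in one place only: hydrogen in place of ethyl on an amide-type nitrogen. The change is a cut of the ethyl(methyl)carbamoyl group to methylcarbamoyl, nothing else in the structure moves.

Among the measured compounds shown here, with no measured step to lean on, the size of the step from compound 3 to compound 4 in this assay cannot be read from data; the working expectation is a small change, most likely none beyond the usual scatter, with a slight lean toward less inhibition. Compound 4 is therefore expected to show 30% in this assay, within a range of 12% to 50%. This estimate means a step of a number 4 percentage points lower from compound 3 to compound 4 (within the scatter), to be checked once the number is known.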

Compound 4, a percentage reported as inhibition, in the whole organism at one dose (the size of the read-out at that dose, not a potency): 28%
The estimate for compound 4 lay 2 percentage points above the measured number; the range from low to high includes it.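

In this assay, the series now has its first readable step, a number 6 percentage points lower from compound 3 to compound 4 (within the scatter), for hydrogen in place of ethyl on an amide-type nitrogen whose other neighbours are a carbonyl carbon and a saturated chain carbon. At this dose and time, the read-out therefore does not separate ethyl(methyl)carbamoyl from methylcarbamoyl, so the ethyl group can be cut at this position without a change beyond the scatter, though this rests on a single pair and says nothing about potency. No measured information bears on why the two compounds read alike.

Still open is whether a longer chain such as propyl or butyl in place of ethyl on this nitrogen would also stay within the scatter of compound 3, or whether the result holds only for the small groups shown here. Also open is how the shared core responds when the carbamoyl group gives way to something of a different kind, such as a carboxylic acid or a primary amine, since neither appears among the compounds shown.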